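Chloro to trifluoromethyl on the pyrazole ring

This account rests on a few compounds, and the source may have more. Where it says the series, first, only, none or still open, it means among the compounds named here.

Measured so far:
compound 1, `C[C@@H]1CCCN1c1c(C#N)c2c(N)ncnc2n1C`: 11 nM
compound 2, `C[C@@H]1CCCN1c1c(C#N)c2c(N)nc(Nc3cn(C)nc3Cl)nc2n1C`: 21 nM

Compound 1 and compound 2 were tested in an assay on isolated protein for inhibition of Leucine-rich repeat serine/threonine-protein kinase 2 variant G2019S (Homo sapiens), read by TR-FRET and LanthaScreen, with stated times of 50 min and 30 min, in the presence of a further agent that is not named here; a lower number here means a stronger inhibitor, a higher number a weaker inhibitor. Within the data shown here, the only step between them, a 1.9-fold higher number from compound 1 to compound 2 (0.28 log units; within the scatter), shows that attaching the (3-chloro-1-methyl-1H-pyrazol-4-yl)amino group left the number within the scatter, so the two compounds cannot be ranked against each other.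

Compound 3, `C[C@@H]1CCCN1c1c(C#N)c2c(N)nc(Nc3cn(C)nc3C(F)(F)F)nc2n1C`, is not yet measured. It differs from compound 2 as follows: trifluoromethyl in place of chloro on an aromatic carbon. Among the measured compounds shown here, no measured step bears directly on this exchange; the one available step only shows that the pyrazole arm as a whole changed little. Compound 3 is therefore expected to stay near compound 2, with the estimated step of a 1.4-fold higher number from compound 2 to compound 3 (0.15 log units; within the scatter). The estimate for compound 3 in this assay is 30 nM, in the range 10 nM to 90 nM.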

Compound 3, half-maximal inhibitory concentration: 358 nM
For compound 3 the middle estimate is 12-fold (1.08 log units) below the measured one; measured number outside the range, above it.
By their numbers in this assay, from the lowest: compounds 1 and 2 (each within the scatter of the next); then compound 3.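

In this assay, among these compounds, the exchange of chloro for trifluoromethyl on the pyrazole ring gives a 17-fold higher number from compound 2 to compound 3 (1.23 log units; beyond the scatter) and so shows that this one carbon matters, which the earlier compounds did not reveal. Among the compounds shown here, the only earlier step added the whole pyrazole arm and stayed within the scatter, so it had made the arm look undemanding. That tolerance holds for the chloro arm and does not carry over to the trifluoromethyl arm. From the compounds shown here alone, whether bromo, ethyl or methoxy at this carbon would keep the number near that of compound 2 remains open. Nothing measured here gives the reason for this large step.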